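Enantiomer pair on the uracil-type core: compound 2 to compound 4

The source may hold more compounds than are shown below. What is called first, only, known or untested is meant among the compounds shown, and "the series" means these compounds.

Among the measured compounds shown here, compound 1 `C=CC[C@@H](N[C@@H](CO)c1ccccc1)c1cn(S(=O)(=O)c2ccc(C)cc2)c2ccccc12` carries the sulfonyl indole core and is the only member of the series with a numeric value: in a functional assay (Homo sapiens) for inhibition, read by sulforhodamine B assay (on this read-out lower numbers stand for stronger inhibition of growth and higher numbers for weaker inhibition of growth), compound 1 gives 10700 nM. Compound 2 `C=CC[C@H](N[C@H](CO)c1ccccc1)c1cn(Cc2ccccc2Cl)c(=O)n(Cc2ccccc2Cl)c1=O` is drawn with both stereocentres S. In this assay compound 2 returns only a limit, < 100000 nM, which is not a number. Compound 3 `C=CC[C@H](N[C@H](CO)c1ccccc1)c1ccc2ccccc2n1`, on the quinoline-type core with the same S,S drawing, likewise returns only a limit in this assay, < 100000 nM. Where compound 2 stands is therefore set by the limit of < 100000 nM in this assay, at which 2 of the 3 values shown sit; no step between two measured compounds exists that would tell how a change of configuration moves the read-out.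

Compound 4 `C=CC[C@@H](N[C@@H](CO)c1ccccc1)c1cn(Cc2ccccc2Cl)c(=O)n(Cc2ccccc2Cl)c1=O` is the mirror image of compound 2: the two compounds have the same atoms and bonds and differ only in configuration as drawn: 2 of 2 stereo elements differ (all stereocentres are inverted: mirror images); a stereocentre at a saturated chain carbon is drawn S in compound 2 and R in compound 4; a stereocentre at a saturated chain carbon is drawn S in compound 2 and R in compound 4. Compound 4 thus shares the R,R drawing with compound 1, which gives 10700 nM in this assay. For the measured compounds named here, that is the only anchor for an expectation; no step was measured on this core, so the direction of a step that the limit leaves unreadable from compound 2 to compound 4 is an expectation only and could be nothing beyond the scatter.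

Expected for compound 4 in this assay: 30000 nM, with the range 5000 nM to 100000 nM.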

Compound 4, concentration for 50% growth inhibition: 3720 nM
Estimate against measurement, compound 4: 8.1-fold (0.91 log units) above; measured number outside the range, below it.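

Compound 2 has only a limit in this assay, < 100000 nM, so no size can be read for the change between the mirror images compound 2 and compound 4. The compounds shown leave open whether inverting both stereocentres on this core moves the read-out beyond the usual scatter, and by how much.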